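The source may report more compounds than this note shows. Statements on the series, on what has been measured and on what is new or still open speak of the compounds shown alone.

Measured in a functional assay on the whole organism for inhibition, with Rattus norvegicus as the target, read by paw edema, with stated times of 30 min and 3 h, at a dose of 0.28 mmol/kg by the oral route; a higher number here means more inhibition at the dose given (going by the name of the read-out), a lower number less inhibition:
compound 1 `COc1ccc(-n2nc(C(=O)Nc3ccccc3OC)nc2-c2cc(OC)c(OC)c(OC)c2)cc1` — 38%
compound 2 `COc1ccc(-n2nc(C(=O)Nc3ccccc3C)nc2-c2cc(OC)c(OC)c(OC)c2)cc1` — 64%
compound 3 `COc1ccc(-n2nc(C(=O)Nc3ccc(C(=O)O)cc3)nc2-c2cc(OC)c(OC)c(OC)c2)cc1` — 95%

Compound 1 stands lowest of the three numbers in this assay. The nearest measured compound is reached by the step of a number 26 percentage points higher from compound 1 to compound 2 (beyond the scatter); the furthest by the step of a number 57 percentage points higher from compound 1 to compound 3 (beyond the scatter). Between the other two lies the step of a number 31 percentage points higher from compound 2 to compound 3 (beyond the scatter).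

Compound 4 `COc1ccc(-n2nc(C(=O)Nc3ccccc3)nc2-c2cc(OC)c(OC)c(OC)c2)cc1` has not yet been measured in this assay. It differs from compound 1 in one place: hydrogen in place of methoxy on an aromatic carbon.

Of the measured steps, a number 26 percentage points higher from compound 1 to compound 2 (beyond the scatter) bears most directly on this change, since it also swaps out the methoxy at the same aromatic carbon, there for methyl; it was modest and beyond the scatter. The two steps to compound 3 exchange the whole aryl group on the amide-type nitrogen and speak less directly to removal of the methoxy alone. On that basis a modest rise in this assay is expected, of roughly a number 17 percentage points higher from compound 1 to compound 4 (beyond the scatter). Compound 4 is therefore estimated at 55%, with a range from 35% to 75%.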

Compound 4, a percentage reported as inhibition, in the whole organism at one dose (the size of the read-out at that dose, not a potency): 69%
The estimate for compound 4 lay 14 percentage points below the measured number; measured number inside the range.
By their numbers in this assay, from the lowest: compound 1; then compounds 2 and 4 (each within the scatter of the next); then compound 3.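

In this assay, the step of a number 31 percentage points higher from compound 1 to compound 4 (beyond the scatter) shows that removing the methoxy alone is enough for a large rise, so 2-methoxyphenyl is a poorer group here than plain phenyl. The step of a number 5 percentage points higher from compound 2 to compound 4 (within the scatter) adds that hydrogen and methyl at this aromatic carbon cannot be told apart, so the methyl of compound 2 is not needed for its higher number. The step of a number 26 percentage points lower from compound 3 to compound 4 (beyond the scatter) leaves the 4-carboxyphenyl of compound 3 as the only aryl group shown that stands beyond the scatter of plain phenyl.

Nothing measured here accounts for any of these steps. Open, as far as these compounds go, is how an amine, a hydroxy or a fluorine at the carbon that carries the methoxy in compound 1 would read at this single oral dose.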